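The source may hold more compounds than are shown below. What is called first, only, known or untested is meant among the compounds shown, and "the series" means these compounds.

Two compounds, built on the same core, have both been tested in a functional assay on A549 cells (Homo sapiens) for antiproliferative activity, read by sulforhodamine B assay, with a stated time of 72 h; a lower number here means a stronger inhibitor of growth, a higher number a weaker inhibitor of growth. Compound 1 `CCc1cc(=O)c2ccc(OCc3cccc(C#N)c3)c(C)c2o1` gives > 31300 nM, which is a limit of the assay and not a number. Compound 2 `CCc1oc2c(C)c(OC)ccc2c(=O)c1Br` gives > 33600 nM, likewise a limit, so compound 2 stands only as a bound, as the limit of > 33600 nM in this assay, at which 1 of the 2 values shown sits, records. Compound 3 `CCc1oc2c(C)c(OCc3ccccc3)ccc2c(=O)c1Br` differs from compound 2 by phenyl in place of hydrogen on a saturated chain carbon bound to an oxygen on an aromatic ring. Among the measured compounds shown here, no measured step covers this change; because compound 1 gives > 31300 nM at its limit, no gain beyond the scatter is expected. The estimate for compound 3 is 40000 nM, between 10000 nM and 150000 nM, most likely again a limit. The expected step is a step that the limit leaves unreadable from compound 2 to compound 3.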

Compound 3, concentration for 50% growth inhibition: > 26700 nM
Compound 3: only a limit was reported (the forecaster's own chance of this, stated with the estimate: 75%); the middle value does not contradict the limit.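

Compound 2 and compound 3 are both recorded only as limits of the assay, and the step between them cannot be read. The compounds shown leave open whether phenyl at that place changes growth inhibition in this assay at all.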